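Added methyl on two related cores: expected effect

The compounds below may be only part of what the source reports. "The series", "measured", "known", "first", "only" and "open" are said of these compounds alone.

Compound 1, `Cc1ccccc1-n1c(S)nnc1COc1ccc(-c2ccccc2)cc1`, and compound 3, `Cc1ccccc1Nc1nnc(COc2ccc(-c3ccccc3)cc2)s1`, share most of their structure but are built on different cores; the difference between the two cores is not broken down here. In a functional assay on the whole organism (strain Wistar) for inhibition, with Rattus norvegicus as the target, read by paw edema, with a stated time of 4 h, at a dose of 10 mg/kg by the oral route (a higher number here means more inhibition at the dose given (going by the name of the read-out), a lower number less inhibition), compound 1 gives 59.1%, and compound 3 gives 29.5%, the lowest of the three numbers and beyond the scatter from both others. Compound 2, `Cc1ccc(-n2c(S)nnc2COc2ccc(-c3ccccc3)cc2)c(C)c1`, differs from compound 1 by methyl in place of hydrogen on an aromatic carbon, and in this assay compound 2 gives 54.5%, a step of a number 4.6 percentage points lower from compound 1 to compound 2 (within the scatter). Compound 4, `Cc1ccc(Nc2nnc(COc3ccc(-c4ccccc4)cc3)s2)c(C)c1`, differs from compound 3 by the same change, (methyl in place of hydrogen on an aromatic carbon). A step of a number 3.5 percentage points lower from compound 3 to compound 4 (within the scatter) is expected because a number 4.6 percentage points lower from compound 1 to compound 2 (within the scatter) lies within the scatter, so no real movement is anticipated. Compound 4 is therefore estimated at 26%, with a likely range from 10% to 42%.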

Compound 4, a percentage reported as inhibition, in the whole organism at one dose (the size of the read-out at that dose, not a potency): 56.8%
For compound 4 the middle estimate is 30.8 percentage points below the measured one; measured number outside the range, above it.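

In this assay, the change from (2-methylphenyl)amino to (2,4-dimethylphenyl)amino gives a number 27.3 percentage points higher from compound 3 to compound 4 (beyond the scatter). The same methyl in place of hydrogen on an aromatic carbon does not carry over unchanged between the two cores: the same change on two cores in this assay, a number 4.6 percentage points lower (within the scatter) from compound 1 to compound 2 and a number 27.3 percentage points higher (beyond the scatter) from compound 3 to compound 4, 31.9 percentage points apart, beyond the scatter of two such steps. For the compounds shown here, with one pair on each core, this shows only that the step differs between these two pairs; it does not show why, or what the change would do on any other core.

Still open, from the compounds shown here alone, is whether a different group at the same place on the ring, such as a methoxy group or a chlorine atom, would follow the methyl on either core. Also open, going by these compounds, is whether a longer chain there, such as ethyl, would behave like methyl.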